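Furanylmethyl for Phenylethyl on the Amine of Compound 1

A few compounds are considered here, and "the series" means these few. Any claim that something is new, unique, unknown or untested is made for them only; others in the source may bear on it.

Compound 1 `C[C@@H](NC1CCN(CCCc2c[nH]c3ccc(-n4cnnc4)cc23)CC1)c1ccccc1`: 0.4 nM
Compound 2 `CNS(=O)(=O)Cc1ccc2[nH]cc(CCCN3CCC(N[C@H](C)c4ccccc4)CC3)c2c1`: 43 nM
Compound 3 `OC[C@H](NC1CCN(CCCc2c[nH]c3ccc(Cn4cncn4)cc23)CC1)c1ccccc1`: 23 nM

In an assay on CHO cells for displacement of a labelled ligand from 5-hydroxytryptamine receptor 1D (Homo sapiens) (a lower number here means a stronger inhibitor, a higher number a weaker inhibitor), compound 1 gives the lowest of the three numbers, 0.4 nM; compound 3 comes nearest with 23 nM, and compound 2 lies furthest with 43 nM. Within the data shown here, the one step measured in one place, a 110-fold higher number from compound 1 to compound 2 (2.03 log units; beyond the scatter), concerns a change on the aromatic carbon of the shared core and so says nothing directly about the amine side.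

Compound 4 `c1cc(CNC2CCN(CCCc3c[nH]c4ccc(-n5cnnc5)cc34)CC2)co1` is made from compound 1 by (furan-3-yl)methyl in place of 1-phenylethyl on an amine nitrogen. Among the measured compounds shown here, no measured step touches this nitrogen; compound 3 differs from compound 1 in two places at once, so its gap can only hint that changes on that side of the molecule are felt. The phenyl ring and the stereocentre both leave. The account therefore expects compound 4 to lose ground in this assay, with a step of a 13-fold higher number from compound 1 to compound 4 (1.10 log units; beyond the scatter).

The estimate for compound 4 in this assay is 5 nM, within 1 nM to 25 nM.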

Compound 4, half-maximal inhibitory concentration: 4.5 nM
Compound 4: the middle estimate sits 1.1-fold (0.05 log units) above what was measured, within the range that was stated.
By their numbers in this assay, from the lowest: compound 1; then compound 4; then compounds 3 and 2 (each within the scatter of the next).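

In this assay the amine nitrogen now has a measured step of its own: (furan-3-yl)methyl in place of 1-phenylethyl gives an 11-fold higher number from compound 1 to compound 4 (1.05 log units; beyond the scatter) and so this position responds to the change. Compound 4 still gives 4.5 nM without the six-membered aromatic ring or the defined stereocentre of compound 1. No supporting evidence bears on this result, and the step alone cannot separate the loss of the phenyl ring, the loss of the stereocentre and the entry of the furan oxygen.

The compounds shown leave open how a plain benzyl group or a (furan-2-yl)methyl group on this nitrogen would compare. They also leave open whether a 1-(furan-3-yl)ethyl group, which keeps the branching carbon, would stand closer to compound 1.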